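The source may report more compounds than this note shows. Statements on the series, on what has been measured and on what is new or still open speak of the compounds shown alone.

Among the measured compounds shown here, compound 1 `O=C(Nc1ccc(Oc2ccnc3[nH]ccc23)cc1)c1cn(-c2ccc(F)cc2)c2ccccc2c1=O` is the lower of the two numbers in a functional assay on HepG2 cells (Homo sapiens) for inhibition, read by MTT assay, with a stated time of 72 h; on this read-out lower numbers stand for stronger inhibition and higher numbers for weaker inhibition; compound 1 gives 450 nM, while compound 2 `COc1ccc(-n2cc(C(=O)Nc3ccc(Oc4ccnc5[nH]ccc45)cc3)c(=O)c3ccccc32)cc1` gives 5950 nM, and the only measured step, a 13-fold higher number from compound 1 to compound 2 (1.12 log units; beyond the scatter), is a methoxy in place of fluoro on an aromatic carbon. Compound 3 `O=C(Nc1ccc(Oc2ccnc3[nH]ccc23)c(F)c1)c1cn(-c2ccc(F)cc2)c2ccccc2c1=O` differs from compound 1 by fluoro in place of hydrogen on an aromatic carbon. For the measured compounds named here, no measured step touches this position, so nothing directly bears on the change; a step no larger than the scatter is expected in this assay, with the estimated step of a 1.1-fold lower number from compound 1 to compound 3 (0.05 log units; within the scatter). Compound 3 is estimated at 400 nM, range 150 nM to 1200 nM.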

Compound 3, half-maximal inhibitory concentration: 270 nM
Beside the measured number, compound 3's estimate is 1.5-fold (0.17 log units) above it, and the stated range covers the measured number.
By their numbers in this assay, from the lowest: compounds 3 and 1 (each within the scatter of the next); then compound 2.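

In this assay, fluoro in place of hydrogen on the six-membered aromatic ring of carbon only gives a 1.7-fold lower number from compound 1 to compound 3 (0.22 log units; within the scatter), so this first change at this position stays within the scatter. Among the compounds shown here, the one earlier step, at a different place, was a 13-fold higher number from compound 1 to compound 2 (1.12 log units; beyond the scatter), so the series now holds one position with a step beyond the scatter and one without. No supporting measurement bears on this result.

From the compounds shown here alone, whether this position stays as flat with a methoxy, an amine or a chlorine remains open. Also open, going by these compounds, is how fluoro here behaves alongside methoxy at the other place.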